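The source may report more compounds than this note shows. Statements on the series, on what has been measured and on what is new or still open speak of the compounds shown alone.

Of the compounds shown here, two have been measured in an assay on isolated protein for binding affinity to leukotriene B4 receptor 1 (Homo sapiens); on this read-out higher numbers stand for weaker inhibition and lower numbers for stronger inhibition. Compound 1 `CCc1cc(-c2ccn(C)n2)c(O)cc1OCCCCCC(C)(C)c1nnn[nH]1` carries a tetrazole at the end of its chain and gives 9.3 nM. Compound 2 `CCc1cc(-c2cc[nH]n2)c(O)cc1OCCCCCOc1ccc(C(=O)O)cc1` ends instead in a carboxy-bearing benzene ring and gives 82 nM, the higher of the two numbers; its nearest neighbour is compound 1, and the gap between them lies beyond the usual scatter.

Compound 3 `CCc1cc(-c2cc[nH]n2)c(O)cc1OCCCCCOc1ccc(CC(=O)O)cc1` has not yet been measured. It differs from compound 2 in one place: carboxymethyl in place of carboxy on an aromatic carbon. For the measured compounds named here, no measured pair showing this kind of change is available, so the expectation rests only on the two values given. Moving the acid one atom further out is expected to leave this assay number roughly where compound 2 stands or somewhat higher, a modest step of a 2.4-fold higher number from compound 2 to compound 3 (0.39 log units; beyond the scatter). Compound 3 is therefore estimated at 200 nM, with a range from 60 nM to 650 nM.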

Compound 3, half-maximal inhibitory concentration: 55 nM
Compound 3: middle estimate off by 3.6-fold (0.56 log units), on the high side, and the stated range ends above it.
By their numbers in this assay, from the lowest: compound 1; then compounds 3 and 2 (each within the scatter of the next).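

In this assay, replacing 4-carboxyphenyl with 4-(carboxymethyl)phenyl gives a 1.5-fold lower number from compound 2 to compound 3 (0.17 log units; within the scatter) and so separates compound 2 from compound 3 by no more than repeat measurements would. On this aromatic carbon, para to a large group, the acid can therefore stand directly on the ring or one carbon further out with no difference that this read-out can resolve. Nothing available accounts for this agreement between the two values. Still open, going by these compounds, is whether a longer chain, such as carboxyethyl, would keep the number in the same range, or whether an amine or a primary amide in place of the acid would move it. Also open, on these data alone, is whether the same swap would give a similarly small step on a compound with a different core or chain.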